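This account rests on a few compounds, and the source may have more. Where it says the series, first, only, none or still open, it means among the compounds named here.

Measured in a functional assay on MDA-MB-453 cells (Homo sapiens) for antiproliferative activity; on this read-out higher numbers stand for weaker inhibition of growth and lower numbers for stronger inhibition of growth:
- compound 1 `CCCCCCNC(=O)c1cc(C#Cc2cc(OC)ccc2OC)ccc1OC`: > 100000 nM (a limit, not a number)
- compound 2 `CCCCCCNC(=O)c1cc(/C=C\c2cc(O)ccc2O)ccc1O`: 4500 nM
- compound 3 `COC(=O)c1cc(/C=C\c2cc(OC)ccc2OC)ccc1OC`: 10900 nM

Compound 1 stands at the limit of > 100000 nM in this assay, at which 1 of the 3 values shown sits. Its true potency in this assay is therefore unknown, and it offers only a boundary to work from.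

The next compound to consider is compound 4 `COC(=O)c1cc(C#Cc2cc(OC)ccc2OC)ccc1OC`, which keeps the core of compound 1 but changes one group: methoxy in place of hexylamino on a carbonyl carbon. The same difference can be read as hexylcarbamoyl to methoxycarbonyl.

Among the compounds with values here, no measured pair isolates this change, so the expectation rests on indirect evidence. Compound 3 also carries methoxycarbonyl, and compound 3 gives 10900 nM, a real number, although its link between the two ends differs from that of compound 4. Compound 2 keeps the hexylcarbamoyl group and gives 4500 nM, so that group can also go with a real number.

The expected change is an at least 5.0-fold lower number from compound 1 to compound 4 (0.69 log units; beyond the scatter), towards stronger inhibition of growth, though its size remains loose and compound 4 could also reach the limit. For compound 4, the estimated value is 20000 nM, with an expected range of 4000 nM to 100000 nM.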

Compound 4, concentration for 50% growth inhibition: > 100000 nM
Compound 4: only a limit was reported (the forecaster's own chance of this, stated with the estimate: 30%); middle value at least 5.0-fold (0.69 log units) from the limit.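

Compound 4 gives > 100000 nM as a limit and not a number. Compound 1 also stands at a limit, so no step can be read between compound 1 and compound 4: the limit of > 100000 nM in this assay, at which 2 of the 4 values shown sit.
As far as these compounds go, how far each compound lies beyond that limit, and whether hexylcarbamoyl and methoxycarbonyl differ at all on this core, stays open.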